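The compounds below may be only part of what the source reports. "The series", "measured", "known", "first", "only" and "open" are said of these compounds alone.

Compound 1 `CCOC(=O)c1cccc(-c2ccc(OCC)cc2)c1` gives 87% in an assay on COS-7 cells for inhibition of patatin-like phospholipase domain-containing protein 2 (Mus musculus), tested at 200 uM; a higher number here means more inhibition at the concentration tested (going by the name of the read-out), a lower number less inhibition.
Compound 2 `CCNS(=O)(=O)c1cccc(-c2ccc(OCC)cc2)c1` gives 46% in this assay.
Compound 3 `CCOc1ccc(-c2cccc(S(=O)(=O)NC)c2)cc1` gives 47% in this assay.

Compound 3 stands second highest of the three numbers; the step of a number 1 percentage points higher from compound 2 to compound 3 (within the scatter) lies within the scatter, whereas the step of a number 40 percentage points lower from compound 1 to compound 3 (beyond the scatter) is large and separates it from the top value. Compound 4 `CCOc1ccc(-c2cccc(C)c2)cc1` differs from compound 3 in one place: methyl in place of methylsulfamoyl on an aromatic carbon. Among the measured compounds shown here, no measured step exchanges a sulfonamide for a plain methyl group. The steps of a number 41 percentage points lower from compound 1 to compound 2 (beyond the scatter) and a number 40 percentage points lower from compound 1 to compound 3 (beyond the scatter) show only that a sulfonamide in place of an ester cost much, and a number 1 percentage points higher from compound 2 to compound 3 (within the scatter) shows that the chain on the sulfonamide nitrogen mattered little. Removing the sulfonamide entirely is therefore open, and the expected step of a number 8 percentage points higher from compound 3 to compound 4 (within the scatter) carries wide uncertainty. Compound 4 is estimated at 55%, with a range from 25% to 85%.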

Compound 4, a percentage reported as inhibition, at one concentration (the size of the read-out at that concentration, not a potency): 54%
For compound 4 the middle estimate is 1 percentage points above the measured one; low and high end bracket the measured number.
By their numbers in this assay, from the lowest: compounds 2, 3 and 4 (each within the scatter of the next); then compound 1.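

With a number 7 percentage points higher from compound 3 to compound 4 (within the scatter) and a number 8 percentage points higher from compound 2 to compound 4 (within the scatter) in this assay, a plain methyl on this aromatic carbon cannot be told apart from methylsulfamoyl or ethylsulfamoyl, so dropping the whole sulfonamide does not measurably change the result. The ester stands apart, with a number 33 percentage points lower from compound 1 to compound 4 (beyond the scatter) showing that methyl also falls well short of ethoxycarbonyl. Nothing measured here gives a reason for this. On these data alone, it remains open whether the ester's high value depends on its ethyl chain or on its carbonyl. A carboxylic acid, a primary amide or a methyl ester at this place could separate these possibilities.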